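The compounds below may be only part of what the source reports. "The series", "measured", "known", "first", "only" and "open" are said of these compounds alone.

Compound 2 `CC(C)(C)COC(=O)N1CCC(Oc2ncnc3c2CCN3c2ccc(S(C)(=O)=O)cc2F)CC1`: 39.8 nM
Compound 3 `CC(C)c1noc(N2CCC(O)CC2)n1`: 50.1 nM
Compound 1 `CC(C)OC(=O)N1CCC(Oc2cccc3c2CCN3c2ccc(S(C)(=O)=O)cc2)CC1`: 501 nM

All three were tested in a functional assay on CHO-K1 cells for agonist activity at Glucose-dependent insulinotropic receptor (Homo sapiens), read by a luciferase reporter, with a stated time of 5 h; on this read-out lower numbers stand for an effect already at smaller amounts and higher numbers for an effect only at larger amounts of compound. Compound 2 shows the lowest of the three numbers; compound 3 lies within the scatter of it, while compound 1 stands beyond the scatter at a higher number. The unmeasured compound 4 `CS(=O)(=O)c1ccc(N2CCc3c(OC4CCN(C5=NCCCN5)CC4)ncnc32)c(F)c1` derives from compound 2 by a single change: a group of 6 heavy atoms (4 carbon, 2 nitrogen; one six-membered non-aromatic ring with 2 hetero atoms) in place of a group of 8 heavy atoms (6 carbon, 2 oxygen; no ring), on an amine nitrogen in a ring. Among the compounds with values here, no measured pair shows a step of this kind, so the data give no calibration for it; the neopentyloxycarbonyl leaves and a six-membered non-aromatic ring with 2 hetero atoms and 1 hydrogen-bond donor enters. Compound 4 is expected to give a higher number than compound 2, a step of a 4.0-fold higher number from compound 2 to compound 4 (0.60 log units; beyond the scatter) judged likely to exceed the scatter. The estimate for compound 4 in this assay is 160 nM, with a range from 30 nM to 900 nM.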

Compound 4, half-maximal effective concentration: 2000 nM
Estimate against measurement, compound 4: 13-fold (1.10 log units) below; measured number above the stated range.
By their numbers in this assay, from the lowest: compounds 2 and 3 (each within the scatter of the next); then compound 1; then compound 4.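

In this assay, within the data shown here, replacing the neopentyloxycarbonyl on the amine nitrogen in the ring with the six-membered non-aromatic ring gives a 50-fold higher number from compound 2 to compound 4 (1.70 log units; beyond the scatter) and so marks this position as sensitive to the change, which the earlier compounds could not show. The rest of the structure is the same in this pair, so the large step belongs to this one place. Nothing among the data shown accounts for its size.

On these data alone, whether the carbonyl leaving, the ring entering or the added hydrogen-bond donor matters most stays open. So does how an acetyl group, a pyrimidine ring or an open-chain amidine would read on the same nitrogen.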